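Notes on the step from compound 3 to compound 4

The compounds below may be only part of what the source reports. "The series", "measured", "known", "first", "only" and "open" are said of these compounds alone.

Among the measured compounds shown here, in a physicochemical assay for solubility, read by HPLC, in phosphate buffer, with a stated time of 20 h, at pH 7.4 (on this read-out lower numbers stand for lower solubility and higher numbers for higher solubility), compound 3 `O=C(Nc1nnc(NC2CCCC2)s1)c1ccc(O[C@H]2CC[C@@H](C(=O)O)CC2)cc1` gives 26000 nM, the lowest of the three numbers so far and beyond the scatter from the other two. Compound 1 `O=C(O)C[C@H]1CC[C@H](c2ccc(C(=O)Nc3nnc(CCC4CCCO4)s3)cc2)CC1` gives 90000 nM and compound 2 `O=C(O)C[C@H]1CC[C@H](c2ccc(C(=O)Nc3nnc(CCC4CCOC4)s3)cc2)CC1` gives 95000 nM. Compound 4 `O=C(Nc1nnc(Nc2ccccc2)s1)c1ccc(O[C@H]2CC[C@@H](C(=O)O)CC2)cc1` has phenyl in place of cyclopentyl on a nitrogen on an aromatic ring. For the measured compounds named here, the only measured single-place step is a 1.1-fold higher number from compound 1 to compound 2 (0.02 log units; within the scatter), within the scatter, and it involves another group, so it bears only weakly on this change. Going by the values given here, no measured step covers this exchange. A small move towards a lower number in this assay is expected, not clearly beyond the scatter: the expected step is a 1.7-fold lower number from compound 3 to compound 4 (0.24 log units; within the scatter). The estimate for compound 4 is 15000 nM, with an expected range of 4000 nM to 45000 nM.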

Compound 4, solubility: < 2000 nM
Compound 4 gave a limit, no number; the forecaster's own chance of this, stated with the estimate: 5%; middle value at least 7.5-fold (0.87 log units) away from the limit.
By their numbers in this assay, from the lowest: compound 3; then compounds 1 and 2 (each within the scatter of the next). At a limit, below all of these: compound 4.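

In this assay, phenyl in place of cyclopentyl on a nitrogen on an aromatic ring gives an at least 13-fold lower number from compound 3 to compound 4 (1.11 log units; beyond the scatter), showing that this position can move the read-out well beyond the scatter. Among the compounds shown here, the only earlier single-place step, a 1.1-fold higher number from compound 1 to compound 2 (0.02 log units; within the scatter), lay within the scatter and involved another group. The value of compound 4 is a limit, and the full size of the step stays unknown: the limit of < 2000 nM in this assay, at which 1 of the 4 values shown sits.

Still open, from the compounds shown here alone, is whether the step follows the aromatic ring or the ring size; cyclohexyl on the same nitrogen would separate the two.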